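Ring swap on the amine side chain of compound 2

The compounds below may be only part of what the source reports. "The series", "measured", "known", "first", "only" and "open" are said of these compounds alone.

Measured so far:
compound 1, `N#Cc1cccc(-c2nc(N)c3cc(CN4CCC(F)CC4)sc3n2)c1`: 2950 nM
compound 2, `Nc1nc(-c2cccc(C(F)(F)F)c2)nc2sc(CN3CC=CC3)cc12`: 2960 nM

In an assay on CHO-K1 cells for antagonist activity at adenosine receptor A1 (Homo sapiens), read by a beta-galactosidase reporter, with stated times of 15 min and 6 h (on this read-out lower numbers stand for stronger inhibition and higher numbers for weaker inhibition), compound 1 gives 2950 nM, and compound 2 gives 2960 nM. Compound 2 holds the higher of the two numbers, yet its gap to compound 1 lies within the scatter, so the two compounds stand level on this read-out.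

For the measured compounds named here, compound 3, `Nc1nc(-c2cccc(C(F)(F)F)c2)nc2sc(CN3CCC(F)CC3)cc12`, is the one compound still without a number. Against compound 2 it shows (a group of 7 heavy atoms (5 carbon, 1 nitrogen, 1 fluorine; one six-membered non-aromatic ring with 1 hetero atom) in place of a group of 5 heavy atoms (4 carbon, 1 nitrogen; one five-membered non-aromatic ring with 1 hetero atom), on a saturated chain carbon bound to an aromatic carbon). Going by the values given here, no measured pair shares this change, so no step size is known for it. Compound 1 already carries the entering ring together with a different aryl substituent and lands where compound 2 lands. The step is therefore expected to stay within the scatter, with no clear direction. Compound 3 is estimated at 3000 nM, within a range of 1200 nM to 7500 nM. The expected step is a 1.0-fold higher number from compound 2 to compound 3 (0.01 log units; within the scatter), nothing beyond the scatter.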

Compound 3, inhibition constant: 3030 nM
For compound 3 the middle estimate is 1.0-fold (0.00 log units) below the measured one; the measured number falls inside the stated range.
By their numbers in this assay, from the lowest: compounds 1, 2 and 3 (each within the scatter of the next).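

In this assay, 4-fluoropiperidin-1-yl in place of the five-membered ring, on a saturated chain carbon bound to an aromatic carbon, gives a 1.0-fold higher number from compound 2 to compound 3 (0.01 log units; within the scatter), so this position accepts the larger fluorinated ring with no change beyond the scatter. For the compounds shown here, with 4-fluoropiperidin-1-yl held fixed, trifluoromethyl in place of cyano on an aromatic carbon gives a 1.0-fold higher number from compound 1 to compound 3 (0.01 log units; within the scatter), which isolates that exchange for the first time and likewise shows no change beyond the scatter. No supporting measurement bears on either result.

The step from compound 2 to compound 3 changes ring size and adds fluorine together, so the two changes cannot be told apart here; plain piperidine would separate them. Going by these compounds, whether any group at this place moves the number remains open, for example morpholine, an open-chain dimethylamino group or a carboxylic acid.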